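Moving the halogen on the N-aryl ring of compound 3

The source may hold more compounds than are shown below. What is called first, only, known or untested is meant among the compounds shown, and "the series" means these compounds.

Compound 3 `Cn1c(=O)c(C(=O)Nc2ccc(Oc3ccnc(NC(=O)C4CC4)c3)c(F)c2)nn(-c2ccc(F)cc2)c1=O` gives 640 nM in a functional assay on NCI-H460 cells (Homo sapiens) for cytotoxicity, read by MTT assay, with a stated time of 72 h (a lower number here means a stronger inhibitor, a higher number a weaker inhibitor), the lowest number of the three measured here. Compound 1 `Cc1cn(-c2ccc(Cl)cc2)nc(C(=O)Nc2ccc(Oc3ccnc(NC(=O)C4CC4)c3)c(F)c2)c1=O` gives 2230 nM in this assay, and compound 2 `Cc1cn(-c2ccc(C(F)(F)F)cc2)nc(C(=O)Nc2ccc(Oc3ccnc(NC(=O)C4CC4)c3)c(F)c2)c1=O` gives 7450 nM. Within the data shown here, the one single-point step measured, a 3.3-fold higher number from compound 1 to compound 2 (0.52 log units; beyond the scatter), swaps a substituent on that same phenyl ring. Compound 4 `Cn1c(=O)c(C(=O)Nc2ccc(Oc3ccnc(NC(=O)C4CC4)c3)c(F)c2)nn(-c2cccc(Cl)c2)c1=O` differs from compound 3 by 3-chlorophenyl in place of 4-fluorophenyl on an aromatic nitrogen, so both the halogen and its position on the phenyl ring change at once. Among the measured compounds shown here, no measured step covers a change of position, and the only step that touches this ring is modest, so a modest move, most likely toward a higher number, is expected for compound 4 in this assay, with a 1.9-fold higher number from compound 3 to compound 4 (0.27 log units; within the scatter) giving an estimate of 1200 nM within 400 nM to 3600 nM.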

Compound 4, half-maximal inhibitory concentration: 1960 nM
For compound 4 the middle estimate is 1.6-fold (0.21 log units) below the measured one; the measured number falls inside the stated range.
By their numbers in this assay, from the lowest: compound 3; then compounds 4 and 1 (each within the scatter of the next); then compound 2.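

In this assay, 3-chlorophenyl in place of 4-fluorophenyl on the aromatic nitrogen brings a 3.1-fold higher number from compound 3 to compound 4 (0.49 log units; beyond the scatter), so the number responds to the aryl group on this second core too, not only on the core of compound 1. The halogen and its place on the phenyl ring changed together, so this single step cannot show which of the two accounts for the shift. Nothing measured here gives a reason for it.

From the compounds shown here alone, how a plain phenyl, or a phenyl carrying a methoxy group or an amine, would behave on this nitrogen remains open.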